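The source may report more compounds than this note shows. Statements on the series, on what has been measured and on what is new or still open speak of the compounds shown alone.

Measured compounds in the series:
- compound 1, `O=S(=O)(NCC1CCN(CCCc2c[nH]c3ccc(-n4cnnc4)cc23)CC1)c1ccccc1`, 6.2 nM in an assay on CHO cells for displacement of a labelled ligand from 5-hydroxytryptamine receptor 1D (Homo sapiens); on this read-out higher numbers stand for weaker inhibition and lower numbers for stronger inhibition
- compound 2, `c1ccc(CNCC2CCN(CCCc3c[nH]c4ccc(-n5cnnc5)cc34)CC2)cc1`, 1.6 nM
- compound 3, `CC(C)=CCCN(C)C1CCN(CCCc2c[nH]c3ccc(-n4cnnc4)cc23)CC1`, 2.6 nM

Compound 3 sits second highest of the three numbers: its nearest neighbour is compound 2, a 1.6-fold higher number from compound 2 to compound 3 (0.21 log units; within the scatter), and its furthest is compound 1, a 2.4-fold lower number from compound 1 to compound 3 (0.38 log units; beyond the scatter). The next compound, compound 4, is `CN(Cc1ccc(S(C)(=O)=O)cc1)C1CCN(CCCc2c[nH]c3ccc(-n4cnnc4)cc23)CC1`; the change from compound 3 is 4-(methylsulfonyl)phenyl in place of 3-methylbut-2-en-1-yl on a saturated chain carbon bound to an amine nitrogen.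

Among the compounds with values here, two measured steps bear on this. The exchange of a phenylsulfonyl for a benzyl on the amine nitrogen gave a 3.9-fold lower number from compound 1 to compound 2 (0.59 log units; beyond the scatter), so an aromatic ring in this region is tolerated well. The exchange of the benzylamino-methyl arm for the methyl(4-methylpent-3-en-1-yl)amino arm, a 1.6-fold higher number from compound 2 to compound 3 (0.21 log units; within the scatter), shows that the alkenyl chain and a benzyl read about alike. Within the data shown here, no measured pair carries the methylsulfonyl substituent on the aromatic ring, so its effect is not known from this set. The expectation is therefore a step of a 1.0-fold lower number from compound 3 to compound 4 (0.02 log units; within the scatter), with no change beyond the scatter the most likely outcome. Compound 4 is estimated at 2.5 nM, within 0.8 nM to 8 nM.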

Compound 4, half-maximal inhibitory concentration: 18 nM
Compound 4: middle estimate off by 7.2-fold (0.86 log units), on the low side; measured number above the stated range.
By their numbers in this assay, from the lowest: compounds 2 and 3 (each within the scatter of the next); then compound 1; then compound 4.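

In this assay, within the data shown here, replacing 3-methylbut-2-en-1-yl with 4-(methylsulfonyl)phenyl on a saturated chain carbon bound to an amine nitrogen gives a 6.9-fold higher number from compound 3 to compound 4 (0.84 log units; beyond the scatter), the only step so far that reaches a higher number beyond the scatter. The tolerance suggested by the benzyl of compound 2 and the alkenyl chain of compound 3 therefore does not extend to every group at this position. No measurement here gives a cause for this step.

The change brings in the aromatic ring and the methylsulfonyl group together, so the compounds shown do not separate their contributions. An unsubstituted phenyl at this position would isolate the ring, and a methoxy or a fluorine in place of the methylsulfonyl would test how specific the step is to that group.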